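Halomethyl Triazoles on HeLa Cells: Weighing a Bis(chloromethyl) Analogue

This account rests on a few compounds, and the source may have more. Where it says the series, first, only, none or still open, it means among the compounds named here.

Compound 1 `FCc1cn(Cc2ccccc2)nn1` is the starting point. In a functional assay on HeLa cells (Homo sapiens), read by colorimetric assay, with a stated time of 72 h (a higher number here means that more compound is needed for the effect, a lower number that less compound is needed), compound 1 gives > 100 ug/mL, which is a limit of the assay rather than a number (the limit of > 100 ug/mL in this assay, at which 1 of the 3 values shown sits). Among the measured compounds shown here, compound 2 `BrCc1cn(Cc2ccccc2)nn1` differs from it only in the halogen on the chain, and in this assay compound 2 gives 2 ug/mL; the step of an at least 50-fold lower number from compound 1 to compound 2 (1.69 log units; beyond the scatter) is the only measured change available. Compound 3 `CC(=O)OC[C@H]1O[C@@H](n2cc(CI)nn2)[C@H](OC(C)=O)[C@@H](OC(C)=O)[C@@H]1OC(C)=O` places an iodomethyl triazole on a different core, and in this assay compound 3 gives 2 ug/mL, level with compound 2 within the scatter. Compound 4 `CC(=O)OC[C@H]1O[C@@H](n2nnc(CCl)c2CCl)[C@H](OC(C)=O)[C@@H](OC(C)=O)[C@@H]1OC(C)=O` differs from compound 3 by 4,5-bis(chloromethyl)-1H-1,2,3-triazol-1-yl in place of 4-(iodomethyl)-1H-1,2,3-triazol-1-yl on a saturated ring carbon. For the measured compounds named here, the measured step from compound 1 to compound 2 shows that exchanging one halogen for another on this chain can shift the number greatly, but no measured pair covers chlorine or a second chloromethyl group, so the direction is uncertain; a step near the scatter is expected in this assay, written as a 1.5-fold higher number from compound 3 to compound 4 (0.18 log units; within the scatter). Compound 4 is therefore estimated at 3 ug/mL, with a range from 1 ug/mL to 10 ug/mL.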

Compound 4, concentration for half-maximal effect: 6 ug/mL
Compound 4: the middle estimate sits 2.0-fold (0.30 log units) below what was measured; measured number inside the range.
By their numbers in this assay, from the lowest: compounds 2 and 3 (each within the scatter of the next); then compound 4. At a limit, above all of these: compound 1.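

In this assay, among the compounds shown here, putting 4,5-bis(chloromethyl)-1H-1,2,3-triazol-1-yl in place of 4-(iodomethyl)-1H-1,2,3-triazol-1-yl on this saturated ring carbon gives a 3.0-fold higher number from compound 3 to compound 4 (0.48 log units; beyond the scatter), the first measured change on the shared core of these two compounds, and it shows that the number responds modestly to the group held at this position. This one swap changes both the halogen and the number of halomethyl groups on the triazole, so the step cannot be assigned to either change alone. Nothing measured here explains the step.

From the compounds shown here alone, a single chloromethyl group on the triazole of the shared core would separate the effect of the halogen from that of the added chain, and that comparison remains open. Going by these compounds, it also remains open how a plain methyl group or an aminomethyl group, neither of which carries a halogen, would read at this position.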